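Bromo in place of ethoxy: notes on compound 3

The source may report more compounds than this note shows. Statements on the series, on what has been measured and on what is new or still open speak of the compounds shown alone.

For the measured compounds named here, in a functional assay on MT4 cells (Homo sapiens) for cytotoxicity (on this read-out lower numbers stand for stronger inhibition and higher numbers for weaker inhibition), compound 2 `CCOc1cc(C)cc(S(=O)(=O)c2cccc(N)c2C#N)c1` gives 9000 nM, the only true number so far. Compound 1 `Cc1cc(C)cc(Sc2cccc(N)c2C#N)c1` gives > 2000 nM in this assay, and this is a limit of the assay, not a number. Going by the values given here, the two entries therefore offer a single firm reference point, and no measured step between compounds is available.

The next compound to be measured is compound 3 `Cc1cc(Br)cc(S(=O)(=O)c2cccc(N)c2C#N)c1`. It carries bromo in place of ethoxy on an aromatic carbon, meta to a large group and meta to a methyl group: bromo in place of ethoxy on an aromatic carbon. Among the compounds with values here, no measured pair isolates this change, so its size has to be judged without precedent.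

The expected step in this assay stays within the usual scatter, with no firm direction: a 1.1-fold higher number from compound 2 to compound 3 (0.05 log units; within the scatter). Within the data shown here, this expectation is anchored on compound 2 at 9000 nM, the only number available. For compound 3 the estimated value is 10000 nM, with an expected range from 3000 nM to 35000 nM.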

Compound 3, half-maximal inhibitory concentration: 133000 nM
Estimate against measurement, compound 3: 13-fold (1.12 log units) below, and the stated range ends below it.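

In this assay, the aromatic carbon meta to a large group and meta to a methyl group proves sensitive to its substituent: bromo in place of ethoxy gives a 15-fold higher number from compound 2 to compound 3 (1.17 log units; beyond the scatter). For the compounds shown here, this is the first measured step, and it shows that the two groups are not interchangeable at this position, with the ethoxy compound giving the stronger inhibition on this read-out. Compound 1 gives only a limit, not a number, so the series still rests on two firm values: the limit of > 2000 nM in this assay, at which 1 of the 3 values shown sits.

One pair cannot separate what is lost with ethoxy from what is gained with bromo, and no measured property of either group is shown, so the step remains without an assigned cause. Methoxy or chloro on the same aromatic carbon would show whether the step follows the ether oxygen, the length of the chain or the halogen, while an amine there would test a different kind of group at this position.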